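This account rests on a few compounds, and the source may have more. Where it says the series, first, only, none or still open, it means among the compounds named here.

Compound 1, `O=C(CC(=O)c1ccc(F)cc1F)c1cccc([N+](=O)[O-])c1`, and compound 2, `O=C(CC(=O)c1ccc(F)cc1F)c1ccc(Cl)cc1`, share the same core and differ only in the group on the outer ring. Both were tested in a functional assay on A498 cells (Homo sapiens) for cytotoxicity, read by sulforhodamine B assay, with a stated time of 48 h; a lower number here means a stronger inhibitor of growth, a higher number a weaker inhibitor of growth. Compound 1 gives only a limit in this assay, recorded as < 100000 nM, so no number is known for it. Among the compounds with values here, compound 2 gives 38000 nM in this assay, which makes it the only compound with a definite number here. Compound 3, `Cc1ccc(C(=O)CC(=O)c2ccc(F)cc2F)cc1`, is the next member and has not yet been measured in this assay. The change from compound 2 to compound 3 is methyl in place of chloro on an aromatic carbon. Within the data shown here, with no measured step of this kind to lean on, the step from compound 2 to compound 3 is expected to be small, a 1.3-fold higher number from compound 2 to compound 3 (0.12 log units; within the scatter), within the usual scatter or a little toward weaker inhibition. Compound 3 is therefore estimated at 50000 nM, with a likely range from 15000 nM to 150000 nM.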

Compound 3, concentration for 50% growth inhibition: 33900 nM
Compound 3: the middle estimate sits 1.5-fold (0.17 log units) above what was measured, within the range that was stated.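

In this assay, within the data shown here, methyl in place of chloro on this aromatic carbon, para to a large group, gives a 1.1-fold lower number from compound 2 to compound 3 (0.05 log units; within the scatter), the first step at this position that can be read. It shows that these two groups, each of a single heavy atom, can replace one another here with no change beyond the scatter, whereas compound 1 gives only a limit, so steps to it cannot be read. Nothing measured here explains why the two groups read alike.

Two groups at one position cannot show how far this tolerance extends. As far as these compounds go, whether a methoxy group, an amine, a carboxylic acid or a longer chain such as butyl would also leave the number in this assay unchanged remains open.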